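Dimethoxyphenyl for Ethylphenyl on the Shared Core

This account rests on a few compounds, and the source may have more. Where it says the series, first, only, none or still open, it means among the compounds named here.

Compound 1 `C=C(Br)C(=O)Nc1cccc(-c2cn3nc(-c4ccc(CC)cc4)sc3n2)c1` carries the lowest number among the three measured compounds: in a functional assay on CCRF-CEM cells (Homo sapiens) for inhibition, read by cell counting, with a stated time of 3 days (on this read-out higher numbers stand for weaker inhibition and lower numbers for stronger inhibition), compound 1 gives 3400 nM. Compound 2 `Nc1cccc(-c2cn3nc(CCc4ccccc4)sc3n2)c1` gives 30000 nM in this assay, and compound 3 `Nc1cccc(-c2cn3nc(Cc4ccc(Cl)cc4)sc3n2)c1` gives 42000 nM. Within the data shown here, the only measured step, a 1.4-fold higher number from compound 2 to compound 3 (0.15 log units; within the scatter), alters a different part of the molecule and lies within the scatter. Compound 4 `C=C(Br)C(=O)Nc1cccc(-c2cn3nc(-c4ccc(OC)c(OC)c4)sc3n2)c1` differs from compound 1 in one place: 3,4-dimethoxyphenyl in place of 4-ethylphenyl on an aromatic carbon. Among the measured compounds shown here, no measured pair exchanges the 4-ethylphenyl on the shared core, so the data give no direct guide, and the expectation is no step beyond the scatter. Compound 4 is therefore expected to give about 3400 nM in this assay, between 1200 nM and 10000 nM, an expected step of no change at the digits printed from compound 1 to compound 4 (within the scatter).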

Compound 4, half-maximal inhibitory concentration: 380 nM
Beside the measured number, compound 4's estimate is 8.9-fold (0.95 log units) above it; measured number outside the range, below it.
By their numbers in this assay, from the lowest: compound 4; then compound 1; then compounds 2 and 3 (each within the scatter of the next).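

Among these compounds, this position on the shared core is sensitive to the group it carries: in this assay, 3,4-dimethoxyphenyl in place of 4-ethylphenyl gives an 8.9-fold lower number from compound 1 to compound 4 (0.95 log units; beyond the scatter) and is the first step beyond the scatter between compounds differing in one place. The entering group has two hydrogen-bond acceptors where the leaving group has none, and two more heavy atoms. No evidence at hand says what lies behind the step.

From the compounds shown here alone, whether a single methoxy group would give the same step stays open. So does the effect of a carboxylic acid or an amine on that phenyl ring.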